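The source may report more compounds than this note shows. Statements on the series, on what has been measured and on what is new or still open speak of the compounds shown alone.

The shared core of compounds 2, 3 and 4 carries a primary amide on a short chain and a benzyloxy group. Compound 2 `NC(=O)Cc1cc(=O)oc2cc(OCc3ccccc3)ccc12` gives 8000 nM in an assay (strain Wistar) for inhibition of Amine oxidase [flavin-containing] A (Rattus norvegicus); on this read-out higher numbers stand for weaker inhibition and lower numbers for stronger inhibition. Compound 3 `NC(=O)Cc1cc(=O)oc2cc(OCc3cccc(Cl)c3)ccc12` gives 26000 nM in this assay and stands highest of the two numbers recorded, with compound 2 nearest. Among the compounds with values here, the step of a 3.3-fold higher number from compound 2 to compound 3 (0.51 log units; beyond the scatter) is the only measured step that bears on the comparison below. Compound 1 `NC(=O)[C@@H]1CCCN1Cc1cc(=O)oc2cc(OCc3cccc(F)c3)ccc12`, with a different amide-bearing group, gives > 100000 nM in this assay, which is a limit of the assay rather than a number (the limit of > 100000 nM in this assay, at which 1 of the 3 values shown sits).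

Compound 4 `NC(=O)Cc1cc(=O)oc2cc(OCc3cccc(F)c3)ccc12` differs from compound 3 by fluoro in place of chloro on an aromatic carbon. Within the data shown here, the one relevant step shows that adding chloro to the unsubstituted compound 2 gave a modestly higher number, so a halogen smaller than chloro is expected to lie between the two measured compounds, and the estimated step is a 1.7-fold lower number from compound 3 to compound 4 (0.24 log units; within the scatter). Compound 4 is therefore expected to give 15000 nM in this assay, with a likely range from 6000 nM to 40000 nM.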

Compound 4, half-maximal inhibitory concentration: 70000 nM
For compound 4 the middle estimate is 4.7-fold (0.67 log units) below the measured one; the measured number lies above the stated range.
By their numbers in this assay, from the lowest: compound 2; then compound 3; then compound 4. At a limit, above all of these: compound 1.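

In this assay, fluoro in place of hydrogen gives an 8.8-fold higher number from compound 2 to compound 4 (0.94 log units; beyond the scatter), and fluoro in place of chloro gives a 2.7-fold higher number from compound 3 to compound 4 (0.43 log units; beyond the scatter). At this place on the aromatic ring, meta to a large group, both halogens thus raise the number over hydrogen, and fluoro raises it further than chloro, so the order among compound 2, compound 3 and compound 4 runs hydrogen, chloro, fluoro. Carbamoyl in place of 2-carbamoylpyrrolidin-1-yl on a saturated chain carbon bound to an aromatic carbon gives an at least 1.4-fold lower number from compound 1 to compound 4 (0.15 log units; that floor lies within the scatter). Compound 1 carries a limit and not a number: the limit of > 100000 nM in this assay, at which 1 of the 4 values shown sits.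

On these data alone, whether this order extends to bromo, methyl or methoxy at the same place remains open. So does whether fluoro and chloro would rank the same way elsewhere on this aromatic ring, or with an amine or a carboxylic acid in place of the primary amide.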